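From 4-methoxyphenyl to 4-fluorophenyl at the assay limit

A few compounds are considered here, and "the series" means these few. Any claim that something is new, unique, unknown or untested is made for them only; others in the source may bear on it.

In a functional assay on HFF cells (Homo sapiens) for cytotoxicity (on this read-out lower numbers stand for stronger inhibition and higher numbers for weaker inhibition), compound 1 (`COc1ccc(S(=O)(=O)NN2C(=S)S/C(=C\c3ccc(Cl)c(Cl)c3)C2O)cc1`) reads > 100000 nM as a limit and not a number. Compound 2 (`O=C1/C(=C/c2ccc(Cl)c(Cl)c2)SC(=S)N1NS(=O)(=O)c1ccccc1`) reads > 100000 nM as a limit of the assay as well. Compound 3 (`O=C1/C(=C/c2ccc(F)c(F)c2F)SC(=S)N1NS(=O)(=O)c1ccccc1`) likewise reads > 100000 nM as a limit. Compound 1 thus stands at the limit of > 100000 nM in this assay, at which 3 of the 3 values shown sit, and cannot be ranked against the others.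

Compound 4 (`O=S(=O)(NN1C(=S)S/C(=C\c2ccc(Cl)c(Cl)c2)C1O)c1ccc(F)cc1`) differs from compound 1 in one place: fluoro in place of methoxy on an aromatic carbon with fluoro in place of methoxy on an aromatic carbon. For the measured compounds named here, the one measured step is a step that the two limits leave unreadable from compound 2 to compound 3 and it concerns a different group, so it offers no size to carry over. Going by the values given here, no step has been measured at the methoxy position.

Because of the limit of > 100000 nM in this assay, at which 3 of the 3 values shown sit, no step beyond the scatter is expected in this assay for this change. The expected a number no higher from compound 1 to compound 4 (the limit leaves the size open) stays within the scatter. For compound 4 the estimated value is 100000 nM with an expected range of 50000 nM to 200000 nM and a reading at the limit is likely.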

Compound 4, half-maximal inhibitory concentration: > 100000 nM
Compound 4: no number, only a limit; the forecaster's own chance of this, stated with the estimate: 85%; the middle value lies on the limit itself.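

No new step can be read from compound 1 to compound 4 in this assay, so fluoro in place of methoxy stays without a size: the limit of > 100000 nM in this assay, at which 4 of the 4 values shown sit.

Left open is where compound 1, compound 2, compound 3 and compound 4 truly lie beyond that limit, and whether any of these changes alters the read-out in this assay.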